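Chloroacetamide added to an unmeasured uracil analogue

The compounds below may be only part of what the source reports. "The series", "measured", "known", "first", "only" and "open" are said of these compounds alone.

Measured so far, in a functional assay on MCF7 cells (Homo sapiens) for inhibition, read by MTT assay, with a stated time of 72 h; on this read-out higher numbers stand for weaker inhibition and lower numbers for stronger inhibition:
Compound 1 `O=c1nc(NO)cc[nH]1` gives > 100000 nM, which is a limit of the assay.
Compound 2 `O=c1ccn(COC(CO)CO)c(=O)[nH]1` gives > 100000 nM, also a limit.
Compound 3 `Nc1cn(COC(CO)CO)c(=O)[nH]c1=O` gives > 100000 nM, again a limit.

On the numbers shown, compound 3 stands where every other compound stands: at the limit of > 100000 nM in this assay, at which 3 of the 3 values shown sit. For the measured compounds named here, the one step between measured compounds, a step that the two limits leave unreadable from compound 2 to compound 3, cannot be read, since both ends sit at the limit. Compound 4 `O=C(CCl)Nc1cn(COC(CO)CO)c(=O)[nH]c1=O` is the next compound, and it differs from compound 3 by (chloromethyl)carbonyl in place of hydrogen on a nitrogen on an aromatic ring. Going by the values given here, no measured step bears on this change, and no step among the three compounds gives a size in either direction, so the expectation for compound 4 can rest only on the position of compound 3 at the limit. The step expected from compound 3 to compound 4 is therefore a number no higher from compound 3 to compound 4 (the limit leaves the size open), meaning none beyond the scatter. Compound 4 is accordingly estimated at 100000 nM, with a range from 30000 nM to 300000 nM, and most likely the assay will again report only a limit.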

Compound 4, half-maximal inhibitory concentration: 32000 nM
Compound 4: middle estimate off by 3.1-fold (0.49 log units), on the high side; low and high end bracket the measured number.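

In this assay, changing amino to ((chloromethyl)carbonyl)amino gives an at least 3.1-fold lower number from compound 3 to compound 4 (0.49 log units; beyond the scatter), which shows that a change at this site on the shared core can register in the read-out. Set against the compound with only hydrogen on that aromatic carbon, the same group gives an at least 3.1-fold lower number from compound 2 to compound 4 (0.49 log units; beyond the scatter). Both sizes are minimums, and the step that adds the amino group alone cannot be read, because the starting compounds sit at a limit: the limit of > 100000 nM in this assay, at which 3 of the 4 values shown sit.

Which part of the new group accounts for the step stays open, and an acetyl group without the chlorine, or a bromoacetyl group, on the same nitrogen would help to separate the parts. Going by these compounds, how large the two steps really are also stays open, as does whether a longer acyl chain would go further.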